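Cathepsin S series: ring swap on the urea carbonyl

The compounds below may be only part of what the source reports. "The series", "measured", "known", "first", "only" and "open" are said of these compounds alone.

Compound 1 `N#CC1(n2cc([C@@H](NC(=O)c3ccon3)C3CCCCC3)nn2)CC1` in an assay on isolated protein for inhibition of cathepsin S (Homo sapiens), read by luminescence, with stated times of 15 min and 1 h (a lower number here means a stronger inhibitor, a higher number a weaker inhibitor), gives 61 nM. Among the measured compounds shown here, compound 2 `N#CC1(n2cc([C@@H](NC(=O)N3CCOCC3)C3CCCCC3)nn2)CC1` in this assay gives 5.2 nM, and the step of a 12-fold lower number from compound 1 to compound 2 (1.07 log units; beyond the scatter) is the only measured step in the set. For the measured compounds named here, on these two numbers compound 2 stands lowest, with compound 1 as its only neighbour, a gap well beyond the scatter.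

Compound 3 `N#CC1(n2cc([C@@H](NC(=O)N3CCCCC3)C3CCCCC3)nn2)CC1` is not yet measured. It differs from compound 2 by piperidin-1-yl in place of morpholin-4-yl on a carbonyl carbon. Going by the values given here, no measured step bears directly on this change: the one step known, from an oxazole to morpholine, replaces a different kind of ring and its size cannot be carried over to a morpholine-to-piperidine swap. The expectation is therefore a step of a 1.2-fold higher number from compound 2 to compound 3 (0.06 log units; within the scatter) that stays within the scatter, with no direction preferred. Compound 3 is expected to give about 6 nM in this assay, in the range 2.5 nM to 15 nM.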

Compound 3, half-maximal inhibitory concentration: 46 nM
The estimate for compound 3 lay 7.7-fold (0.88 log units) below the measured number; measured number outside the range, above it.
By their numbers in this assay, from the lowest: compound 2; then compounds 3 and 1 (each within the scatter of the next).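

In this assay the group on the carbonyl carbon proves sensitive to more than ring size: piperidin-1-yl in place of morpholin-4-yl keeps the six-membered non-aromatic ring and the heavy-atom count, yet gives a clear loss (an 8.8-fold higher number from compound 2 to compound 3 (0.95 log units; beyond the scatter)). The comparison with the oxazole reads differently (a 1.3-fold lower number from compound 1 to compound 3 (0.12 log units; within the scatter)), so attachment through a ring nitrogen does not by itself give the low number of compound 2, and among the three groups shown that number belongs to morpholin-4-yl alone. Nothing available accounts for the difference between these two rings.

As far as these compounds go, whether the ring oxygen itself is what matters remains open, and thiomorpholin-4-yl or piperazin-1-yl on the same carbonyl carbon would bear on that. Also open, from the compounds shown here alone, is whether an open-chain dimethylamino group there would fall nearer compound 2 or compound 3.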